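From compound 3 to compound 4: a new acid group

The source may hold more compounds than are shown below. What is called first, only, known or untested is meant among the compounds shown, and "the series" means these compounds.

In a functional assay on DU-145 cells (Homo sapiens) for cytotoxicity, read by trypan blue exclusion, with a stated time of 96 h (on this read-out higher numbers stand for weaker inhibition and lower numbers for stronger inhibition), compound 3 (`COc1cc(OC)c(/C=C/S(=O)(=O)Cc2ccc(OC)c(NC(C)(C)C(=O)O)c2)c(OC)c1`) gives 150 nM as the lowest of three numbers. Compound 1 (`COC(=O)C(C)(C)Nc1cc(CS(=O)(=O)/C=C/c2c(OC)cc(OC)cc2OC)ccc1OC`) gives 2500 nM and compound 2 (`COc1cc(OC)c(/C=C/S(=O)(=O)Cc2ccc(OC)c(NCCC(=O)O)c2)c(OC)c1`) gives 5000 nM and these two lie within the usual scatter of each other. Compound 4 (`COc1cc(OC)c(/C=C/S(=O)(=O)Cc2ccc(OC)c(NC(C(=O)O)c3ccc(Cl)cc3)c2)c(OC)c1`) has not been measured yet. Among the measured compounds shown here, it carries carboxy(4-chlorophenyl)methyl in place of 1-carboxy-1-methylethyl on a nitrogen on an aromatic ring and so gains a ring that no measured compound has in this group.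

For the measured compounds named here, two measured steps bear on this change. Going from methyl ester to free acid came with a 17-fold lower number from compound 1 to compound 3 (1.22 log units; beyond the scatter) as a large step. Changing only the chain that carries the acid came with a 33-fold lower number from compound 2 to compound 3 (1.52 log units; beyond the scatter) as another large step. Compound 4 keeps the acid, but this group can clearly move the number a long way. The expected step in this assay is a 2.7-fold higher number from compound 3 to compound 4 (0.43 log units; beyond the scatter) and points to weaker inhibition, though smaller than those two. The estimate for compound 4 is 400 nM with an expected range from 80 nM to 2000 nM in this read-out.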

Compound 4, half-maximal inhibitory concentration: 400 nM
For compound 4 middle estimate and measured number coincide at the digits printed, and the stated range covers the measured number.
By their numbers in this assay, from the lowest: compound 3; then compound 4; then compounds 1 and 2 (each within the scatter of the next).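

In this assay, the nitrogen substituent can gain a six-membered aromatic ring and a chlorine at only a modest cost (a 2.7-fold higher number from compound 3 to compound 4 (0.43 log units; beyond the scatter)), so carboxy(4-chlorophenyl)methyl is tolerated here. The low number also does not depend on 1-carboxy-1-methylethyl alone. The new group still gives clearly lower numbers than the other two compounds (a 13-fold lower number from compound 2 to compound 4 (1.10 log units; beyond the scatter); a 6.3-fold lower number from compound 1 to compound 4 (0.80 log units; beyond the scatter)). Nothing measured here explains why this step is so much smaller than those earlier ones.

The part played by the chlorine remains open, since the compounds shown do not include carboxy(phenyl)methyl, the same group without it. Also open, going by these compounds, is whether a methyl ester in place of the carboxylic acid of compound 4 would raise the number as it does for the acid of compound 3.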